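This account rests on a few compounds, and the source may have more. Where it says the series, first, only, none or still open, it means among the compounds named here.

Measured so far in an ADME assay on HepG2 cells (Homo sapiens) for cytotoxicity, read by luminescence, with a stated time of 72 h; a higher number here means that more compound is needed for the effect, a lower number that less compound is needed:

- compound 1 `CCOC(=O)c1c(-c2cccc(Cl)c2)[nH]c2cc(OC)ccc2c1=O` gives > 21500 nM as a limit
- compound 2 `CCOC(=O)c1c(-c2cccc(-c3ccccc3)c2)[nH]c2cc(OC(C)C)ccc2c1=O` gives > 21500 nM as a limit
- compound 3 `CCOC(=O)c1c(-c2cccc(OC)c2)[nH]c2cc(OC(C)C)ccc2c1=O` gives > 21500 nM as a limit

Compound 3 has no number and stands only at a limit of > 21500 nM in this assay as its reading. Within the data shown here, the whole series sits at one reading, the limit of > 21500 nM in this assay, at which 3 of the 3 values shown sit, and no measured compound has a number.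

Compound 4 `CCOC(=O)c1c(-c2cccc(OC)c2)[nH]c2cc(C(F)(F)F)ccc2c1=O` differs from compound 3 in one place, with trifluoromethyl in place of isopropoxy on an aromatic carbon and the rest of the shared core is unchanged. Among the measured compounds shown here, no measured compound carries trifluoromethyl. For the measured compounds named here, the only measured step is a different change, methoxy in place of phenyl on an aromatic carbon, and it is a step that the two limits leave unreadable from compound 2 to compound 3 so it offers no size to carry over.

No step beyond the scatter is therefore expected in this assay and no direction can be given. Another limit reading is the most likely outcome. This estimate means a step that the limit leaves unreadable from compound 3 to compound 4 as the expected step. The estimate for compound 4 is 25000 nM with 12000 nM to 50000 nM as the expected range.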

Compound 4, half-maximal effective concentration: > 21500 nM
Compound 4: a limit, no number; the forecaster's own chance of this, stated with the estimate: 80%; the middle value is on the limit's open side.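

Compound 3 and compound 4 both stand only at a limit, so no step can be read between them for trifluoromethyl in place of isopropoxy on an aromatic carbon in this assay: the limit of > 21500 nM in this assay, at which 4 of the 4 values shown sit.

The compounds shown leave open what number any of them would give in this assay, and whether any change on the shared core would shift it.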